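A Stereochemical Flip with No Measured Precedent

The source may report more compounds than this note shows. Statements on the series, on what has been measured and on what is new or still open speak of the compounds shown alone.

Compound 1 `CS(=O)(=O)Nc1ccc2c(c1)S(=O)(=O)N=C(C1=C(O)[C@@H]3[C@H]4CC[C@H](C4)[C@@H]3N(Cc3ccccc3Cl)C1=O)N2` — > 1 h
Compound 2 `CS(=O)(=O)Nc1ccc2c(c1)S(=O)(=O)N=C(C1=C(O)[C@@H]3[C@H]4CC[C@H](C4)[C@@H]3N(CC3CCCCC3)C1=O)N2` — 0.733 h

In an in vitro ADME assay on microsomes from liver (Homo sapiens) for metabolic stability, tested at 1 uM (on this read-out lower numbers stand for a shorter-lived compound and higher numbers for a longer-lived compound), compound 1 gives > 1 h, which is a limit of the assay rather than a number. In this assay compound 2 gives 0.733 h, the only number shown. The other value shown is the limit of > 1 h in this assay, at which 1 of the 2 values shown sits. Compound 3 `CS(=O)(=O)Nc1ccc2c(c1)S(=O)(=O)N=C(C1=C(O)[C@@H]3[C@@H]4CC[C@@H](C4)[C@@H]3N(CC3CCCCC3)C1=O)N2` is not yet measured. It differs from compound 2 thus: the two compounds have the same atoms and bonds and differ only in configuration as drawn: 2 of 4 stereo elements differ; a stereocentre at a saturated ring carbon is drawn S in compound 2 and R in compound 3; a stereocentre at a saturated ring carbon is drawn R in compound 2 and S in compound 3. Among the compounds with values here, the one measured step, an at least 1.3-fold lower number from compound 1 to compound 2 (0.13 log units; that floor lies within the scatter), swaps a substituent and says nothing about a change of configuration. Within the data shown here, with no guiding step, the expected step is a 1.0-fold lower number from compound 2 to compound 3 (0.00 log units; within the scatter), none beyond the scatter. Compound 3 is estimated at 0.73 h, between 0.35 h and 1.5 h.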

Compound 3, half-life: 0.25 h
Compound 3: the middle estimate sits 2.9-fold (0.47 log units) above what was measured, and the stated range ends above it.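

In this assay, changing configuration alone is enough to move the result beyond the scatter, with a 2.9-fold lower number from compound 2 to compound 3 (0.47 log units; beyond the scatter). Within the data shown here, the earlier step swapped a substituent, whereas here the drawing changes at only two saturated ring carbons. The shorter half-life can therefore be put down to configuration and not to any change of group, because no atom or bond differs: the fact that compounds 2 and 3 differ only in the configuration as drawn.

Going by these compounds, whether the same flip would shorten the half-life with 2-chlorophenyl in place of cyclohexyl stays open. So does its effect with a group such as an amine or a carboxylic acid on that chain, or at the other two stereo elements.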